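The source may hold more compounds than are shown below. What is called first, only, known or untested is meant among the compounds shown, and "the series" means these compounds.

In an assay on isolated protein for inhibition of DNA topoisomerase 1 (Homo sapiens), with a stated time of 30 min, tested at 100 uM (on this read-out higher numbers stand for more inhibition at the one concentration tested (going by the name of the read-out) and lower numbers for less inhibition), three compounds have been measured. Compound 1 `Cc1ccsc1-c1cc(-c2ccoc2)cc(-c2ccc(Cl)cc2)n1` gives 85.9% in this assay, compound 2 `Cc1ccc(-c2cc(-c3ccoc3)cc(-c3ccc(Cl)s3)n2)o1` gives 13.2%, and compound 3 `Cc1ccccc1-c1cc(-c2ccoc2)cc(-c2ccc(Cl)s2)n1` gives 4.6%. Compound 3 therefore sits at the low end of the three: its number lies within the scatter of that of compound 2, while compound 1 stands far above both, well beyond the scatter. Among the compounds with values here, the only one-place step among the measured compounds is a number 8.6 percentage points lower from compound 2 to compound 3 (within the scatter).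

Compound 4 `Clc1ccc(-c2cc(-c3ccoc3)cc(-c3ccccc3Cl)n2)s1` carries chloro in place of methyl on an aromatic carbon. Within the data shown here, no measured step swaps a methyl for a chloro, so the step from compound 2 to compound 3 bears on this change only loosely, by showing that replacing the group at that point of the shared core left the number essentially where it was. Among the measured compounds shown here, nothing among the measured compounds points to a rise toward the level of compound 1, and nothing points to a fall, since compound 3 already lies near the bottom of the read-out. The estimated step of a number 4.4 percentage points higher from compound 3 to compound 4 (within the scatter) is expected to stay within the scatter. Compound 4 is thus expected to give 9% in this assay, with a range from 0% to 30%.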

Compound 4, a percentage reported as inhibition, at one concentration (the size of the read-out at that concentration, not a potency): 0%
Beside the measured number, compound 4's estimate is 9 percentage points above it; the range from low to high includes it.
By their numbers in this assay, from the lowest: compounds 4, 3 and 2 (each within the scatter of the next, the first and the last beyond it); then compound 1.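

In this assay, putting chloro in place of methyl on the six-membered aromatic ring of carbon only, which turns 2-methylphenyl into 2-chlorophenyl, gives a number 4.6 percentage points lower from compound 3 to compound 4 (within the scatter), so this exchange does not separate the two compounds on this read-out. The comparison with the 5-methylfuran-2-yl group now gives a number 13.2 percentage points lower from compound 2 to compound 4 (beyond the scatter), a modest step beyond the scatter, whereas the earlier comparison of that group with 2-methylphenyl stayed within it. No measurement at hand explains either step.

With compound 4 at 0%, the read-out has no room to show any further fall here, so at this position only a rise could be told apart from these low numbers. Going by these compounds, whether an amine, a hydroxyl or a carboxylic acid on this six-membered ring would lift the number remains open, as does whether the change from methyl to chloro would also leave the number in place on a compound with a much higher reading.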